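This account rests on a few compounds, and the source may have more. Where it says the series, first, only, none or still open, it means among the compounds named here.

In a toxicity assay on MT2 cells (Homo sapiens) for cytotoxicity, read by XTT assay, with a stated time of 4 days (a lower number here means that less compound is tolerated, a higher number that more compound is tolerated), compound 1 (`Cc1nc([C@H](NC(=O)c2ccc(-c3ccc(Cl)c(F)c3)[nH]2)[C@H]2CCCCN2)sc1CO`) gives 26000 nM and compound 2 (`Cc1ccc(-c2ccc(C(=O)N[C@H](c3nc(C)c(CO)s3)[C@@H]3CCCCN3)[nH]2)cc1F`) gives 16100 nM while compound 3 (`Cc1ccc(-c2ccc(C(=O)N[C@@H](c3nc(C)c(CO)s3)[C@@H]3CCCCN3)[nH]2)cc1F`) gives 28200 nM on the same read-out. Compound 2 lies within the scatter of both others, so the numbers do not set it apart. Compound 4 (`Cc1ccc(-c2ccc(C(=O)N[C@H](c3nc(C)c(CCO)s3)[C@@H]3CCCCN3)[nH]2)cc1F`) differs from compound 2 thus: hydroxymethyl in place of hydroxy on a saturated chain carbon bound to an aromatic carbon (hydroxymethyl to 2-hydroxyethyl). For the measured compounds named here, the one measured step, a 1.8-fold higher number from compound 2 to compound 3 (0.24 log units; within the scatter) and within the scatter, reflects the fact that compounds 2 and 3 differ only in the configuration as drawn and leaves this chain untouched. Going by the values given here, with compound 2 at 16100 nM and no measured step on this chain, no shift beyond the scatter is expected in this assay for this change. The estimated outcome is a 1.2-fold higher number from compound 2 to compound 4 (0.09 log units; within the scatter) as the expected step. For compound 4 the expected value is 20000 nM (estimated range 9000 nM to 45000 nM).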

Compound 4, half-maximal cytotoxic concentration: 29700 nM
Compound 4: middle estimate off by 1.5-fold (0.17 log units), on the low side; measured number inside the range.
By their numbers in this assay, from the lowest: compounds 2, 1, 3 and 4 (each within the scatter of the next).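

In this assay, for the compounds shown here, the change from hydroxymethyl to 2-hydroxyethyl gives a 1.8-fold higher number from compound 2 to compound 4 (0.27 log units; within the scatter), the only measured step on this chain. Compounds 2 and 4 are therefore not separated on this read-out, and this position accepts either chain without a shift beyond the scatter. The available evidence offers no cause for this step.

Open, from the compounds shown here alone, is whether an amine, a carboxylic acid or a longer chain such as 3-hydroxypropyl at this place would also stay within the scatter of compound 2. Also open, going by these compounds, is how 2-hydroxyethyl reads with the configuration drawn in compound 3.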